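This account rests on a few compounds, and the source may have more. Where it says the series, first, only, none or still open, it means among the compounds named here.

Measured compounds:
- Compound 1 `Cc1ccccc1S(=O)(=O)NC(=O)c1ccc(Nc2nc(NC3(c4ccc(Cl)cc4)CC3)nc(OCC(F)(F)F)n2)cc1` gives 100% in an ADME assay on microsomes from liver (Homo sapiens) for metabolic stability, with a stated time of 10 min; a lower number here means that less of the compound is left, a higher number that more of the compound is left.
- Compound 2 `CC(C)(C)OC(=O)NCCS(=O)(=O)NC(=O)c1ccc(Nc2nc(NC3(c4ccc(Cl)cc4)CC3)nc(OCC(F)(F)F)n2)cc1` gives 92% in this assay.
- Compound 3 `CC(C)(C)CNCCS(=O)(=O)NC(=O)c1ccc(Nc2nc(NC3(c4ccc(Cl)cc4)CC3)nc(OCC(F)(F)F)n2)cc1` gives 89% in this assay.

All three compounds share the same core and differ only in the group attached to the sulfonyl sulfur. Compound 1 holds the largest of the three numbers, although its gap to compound 2, a number 8 percentage points lower from compound 1 to compound 2 (within the scatter), lies within the scatter; only its gap to compound 3, a number 11 percentage points lower from compound 1 to compound 3 (beyond the scatter), goes beyond it, and even that step is modest. Between compound 2 and compound 3 the step is a number 3 percentage points lower from compound 2 to compound 3 (within the scatter).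

Compound 4 `CN(C)S(=O)(=O)NC(=O)c1ccc(Nc2nc(NC3(c4ccc(Cl)cc4)CC3)nc(OCC(F)(F)F)n2)cc1` is the next compound in this series. Relative to compound 1 the change is dimethylamino in place of 2-methylphenyl on a sulfonyl sulfur. The two measured steps that bear on it are the ones that also swap the group on the sulfonyl sulfur of compound 1: a number 8 percentage points lower from compound 1 to compound 2 (within the scatter) and a number 11 percentage points lower from compound 1 to compound 3 (beyond the scatter). Both replacements left most of the compound intact, so for compound 4 a step of similar size is expected in this assay, small and, if anything, downward. The estimate for compound 4 is therefore 93%, with a range from 80% to 100%, which corresponds to an expected step of a number 7 percentage points lower from compound 1 to compound 4 (within the scatter).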

Compound 4, percent of the compound remaining: 86%
Beside the measured number, compound 4's estimate is 7 percentage points above it; the range from low to high includes it.
By their numbers in this assay, from the lowest: compounds 4, 3, 2 and 1 (each within the scatter of the next, the first and the last beyond it).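

In this assay, replacing the 2-methylphenyl ring with dimethylamino, which turns the (2-methylphenyl)sulfonyl group into dimethylsulfamoyl, gives a number 14 percentage points lower from compound 1 to compound 4 (beyond the scatter), so a small group without a ring also leaves most of the compound intact at this position. Compared with the two longer chains, the readings are a number 3 percentage points lower from compound 3 to compound 4 (within the scatter) and a number 6 percentage points lower from compound 2 to compound 4 (within the scatter), so compounds 2, 3 and 4 cannot be told apart here even though their groups on the sulfonyl sulfur differ widely in size, and only compound 2 stays within the scatter of compound 1, which keeps any advantage of the 2-methylphenyl ring from holding against all three. Nothing shown here explains why these numbers fall as they do.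

As far as these compounds go, it remains open whether a plain methyl group, a cyclic amine such as morpholine, or a pyridine ring on the sulfonyl sulfur would read like compound 1 or like compound 4. From the compounds shown here alone, it is also open whether the same replacements would behave alike if the 2,2,2-trifluoroethoxy group on the shared core gave way to a simple methoxy group.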